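The compounds below may be only part of what the source reports. "The series", "measured", "known", "first", "only" and "open" are said of these compounds alone.

Working notes on the series. Compound 3 `Cc1ccc(O)c(C(=O)c2cccnc2)c1` carries a hydroxy and a methyl on the shared core; in a functional assay on HeLa cells (Homo sapiens) for cytotoxicity, read by sulforhodamine B assay, with a stated time of 48 h (on this read-out lower numbers stand for stronger inhibition and higher numbers for weaker inhibition), compound 3 gives 26000 nM. Compound 1 `O=C(c1cccnc1)c1cc(Cl)ccc1O` is its chloro analogue, the counted difference being (chloro in place of methyl on an aromatic carbon), and in this assay compound 1 gives 24000 nM, so that the step is a 1.1-fold lower number from compound 3 to compound 1 (0.03 log units; within the scatter). Compound 2 `C=CCOc1ccc(C)cc1C(=O)c1cccnc1` differs from compound 3 in the core, the counted difference being (allyl in place of hydrogen on an oxygen on an aromatic ring); in this assay compound 2 gives 94000 nM, the highest number of the three measured, and the step is a 3.6-fold lower number from compound 2 to compound 3 (0.56 log units; beyond the scatter).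

Compound 4 `C=CCOc1ccc(Cl)cc1C(=O)c1cccnc1` has not yet been measured. It stands to compound 2 as compound 1 stands to compound 3, the counted difference being (chloro in place of methyl on an aromatic carbon). Among the measured compounds shown here, this is the same kind of change as the one from compound 3 to compound 1, not the same change: there the chloro enters para to a hydroxy group, here para to an allyloxy group. For the measured compounds named here, nothing measured so far tells whether the allyloxy group alters the outcome of this exchange.

Going by the values given here, the expected step is a 1.0-fold lower number from compound 2 to compound 4 (0.02 log units; within the scatter), set beside the earlier one, because a 1.1-fold lower number from compound 3 to compound 1 (0.03 log units; within the scatter) stayed within the scatter in the one place where this exchange has been measured. Compound 4 is therefore expected to give about 90000 nM in this assay. Compound 4 is estimated to fall between 45000 nM and 180000 nM.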

Compound 4, half-maximal inhibitory concentration: 75000 nM
Estimate against measurement, compound 4: 1.2-fold (0.08 log units) above; the measured number falls inside the stated range.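

In this assay, chloro in place of methyl on an aromatic carbon again leaves the number within the scatter, with a 1.3-fold lower number from compound 2 to compound 4 (0.10 log units; within the scatter), and this exchange reads the same whether the oxygen carries hydrogen or allyl: the same change on two cores in this assay, a 1.1-fold lower number (0.03 log units; within the scatter) from compound 3 to compound 1 and a 1.3-fold lower number (0.10 log units; within the scatter) from compound 2 to compound 4, 1.2-fold (0.06 log units) apart, within the scatter of two such steps The allyl change also carries across, since putting allyl in place of hydrogen on the oxygen gives a 3.1-fold higher number from compound 1 to compound 4 (0.49 log units; beyond the scatter), and this rise matches in size the one seen with methyl on the core: the same change on two cores in this assay, a 3.6-fold lower number (0.56 log units; beyond the scatter) from compound 2 to compound 3 and a 3.1-fold lower number (0.49 log units; beyond the scatter) from compound 4 to compound 1, 1.2-fold (0.06 log units) apart, within the scatter of two such steps Across these four compounds, the two changes therefore behave independently of one another, but this rests on a single pair of steps for each change, in one cell line and at one stated time, and it shows neither why the allyl compounds give higher numbers nor that the same independence would hold for any other group.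

The compounds shown leave open whether a fluoro, a nitrile or a trifluoromethyl in place of the chloro would also stay within the scatter. They also leave open whether a longer chain, an amine or a carboxylic acid on the oxygen would follow the allyl step or depart from it.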